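Fluoro for hydrogen on the distal ring in two cores

This account rests on a few compounds, and the source may have more. Where it says the series, first, only, none or still open, it means among the compounds named here.

Compound 1 `CCOc1ccc(-c2ccc(NCc3ccccc3O)cc2)cc1` gives 520 nM in a functional assay on Jurkat cells (Homo sapiens) for activation, with a stated time of 24 h; a lower number here means that less compound is needed, a higher number that more compound is needed for the effect. Compound 2 `CCOc1ccc(-c2ccc(NCc3ccccc3O)cc2)cc1F` carries a fluoro in place of hydrogen on an aromatic carbon and gives 2530 nM in this assay; the step of a 4.9-fold higher number from compound 1 to compound 2 (0.69 log units; beyond the scatter). Compound 3 `Oc1ccccc1CNc1ccc(-c2ccccc2)nc1` gives 840 nM in this assay; the difference between the cores of compound 1 and compound 3 is not broken down here. Compound 4 `Oc1ccccc1CNc1ccc(-c2ccc(F)cc2)nc1` carries a fluoro in place of hydrogen on an aromatic carbon relative to compound 3. This is the same kind of change as that from compound 1 to compound 2, not the same: there the place was ortho to an ethoxy group and meta to a large group, here it is para to a large group. Because a 4.9-fold higher number from compound 1 to compound 2 (0.69 log units; beyond the scatter), the step of a 2.0-fold higher number from compound 3 to compound 4 (0.31 log units; beyond the scatter) is expected, read more cautiously for the different place. Compound 4 is estimated at 1700 nM in this assay, between 700 nM and 4200 nM.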

Compound 4, half-maximal effective concentration: 2590 nM
Estimate against measurement, compound 4: 1.5-fold (0.18 log units) below; low and high end bracket the measured number.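

In this assay fluoro in place of hydrogen on the core of compound 3 gives a 3.1-fold higher number from compound 3 to compound 4 (0.49 log units; beyond the scatter) and so runs in the same direction as on the core of compound 1. Set beside the earlier step, the size of the change also carries over between these two cores: the same change on two cores in this assay, a 4.9-fold higher number (0.69 log units; beyond the scatter) from compound 1 to compound 2 and a 3.1-fold higher number (0.49 log units; beyond the scatter) from compound 3 to compound 4, 1.6-fold (0.20 log units) apart, within the scatter of two such steps. This rests on two pairs only, with the fluoro in a different place on each core, so it does not show that the step would hold on further cores or separate the effect of the core from that of the place.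

Still open, going by these compounds, is how chloro, methyl or methoxy would read in place of fluoro on the 4-fluorophenyl ring of compound 4. Also open, on these data alone, is how an amine or a carboxylic acid would read there.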